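Removing a Methyl from Compound 2: What to Expect

This account rests on a few compounds, and the source may have more. Where it says the series, first, only, none or still open, it means among the compounds named here.

Measured compounds:
compound 1, `Cc1cc(O)cc(-c2nn(CC#N)cc2-c2ccnc(-c3ccc(Oc4ccccc4)cc3)c2)c1`, 91%
compound 2, `COc1cc(C)cc(-c2nn(CC#N)cc2-c2ccnc(-c3ccc(N(C)C)cc3)c2)c1`, 15%

Both compounds were tested in a functional assay on HCT-15 cells (Homo sapiens) for cytotoxicity, read by sulforhodamine B assay, with a stated time of 48 h, tested at 100 nM; a lower number here means a stronger effect, a higher number a weaker effect of the compound at the concentration tested. Compound 2 gives 15%, the lowest of the two numbers and therefore the stronger effect; compound 1 gives 91%, a number far enough above that of compound 2 to lie beyond the usual scatter. The two compounds differ in more than one place, so their gap cannot be tied to any single change.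

Compound 3, `Cc1cc(O)cc(-c2nn(CC#N)cc2-c2ccnc(-c3ccc(N(C)C)cc3)c2)c1`, has not yet been measured. It differs from compound 2 in one place: hydrogen in place of methyl on an oxygen on an aromatic ring. Compound 1 also carries the hydroxy group, but its other differences from compound 3 prevent a direct reading of what the change alone does.

Among the measured compounds shown here, with no step between measured compounds, the direction of a number 20 percentage points higher from compound 2 to compound 3 (beyond the scatter) is expected to be a moderate weakening, a move upward from compound 2, though a result within the scatter of compound 2 remains plausible. Compound 3 is estimated at 35%, with a range from 10% to 80%.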

Compound 3, a percentage reported as activity, at one concentration (the size of the read-out at that concentration, not a potency): 90%
Beside the measured number, compound 3's estimate is 55 percentage points below it, outside the stated range (above it).
By their numbers in this assay, from the lowest: compound 2; then compounds 3 and 1 (each within the scatter of the next).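

In this assay the methyl on this oxygen turns out to matter a great deal: methoxy to hydroxy, the loss of one carbon, gives a number 75 percentage points higher from compound 2 to compound 3 (beyond the scatter) and removes nearly all of the effect seen with the 3-methoxy-5-methylphenyl group. The second step, with the hydroxy group held fixed, is a number 1 percentage points lower from compound 1 to compound 3 (within the scatter) for dimethylamino in place of phenoxy, so dimethylamino does not restore the effect when the hydroxy group is present, and the effect seen with compound 2 requires more than that group alone. Nothing available here explains why a single methyl has such weight at this position.

From the compounds shown here alone, it remains open whether the methyl is specifically required or whether a longer chain on the oxygen, such as ethyl, would keep the effect, and whether an amine in place of the oxygen would behave like the hydroxy group. Also open, going by these compounds, is how phenoxy would read alongside the methoxy group, since the step between phenoxy and dimethylamino is known only with the hydroxy group in place.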